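Swapping the dibromophenyl of compound 1 for a methoxy-methylphenyl

A few compounds are considered here, and "the series" means these few. Any claim that something is new, unique, unknown or untested is made for them only; others in the source may bear on it.

Compound 1 `Cc1oc(-c2c(Br)cccc2Br)nc1CN1CCC(C(=O)NCCCN2C[C@H](C)C[C@H](C)C2)CC1`: 6500 nM
Compound 2 `Cc1ccccc1-c1nc(CN2CCC(C(=O)NCCN3C[C@H](C)C[C@H](C)C3)CC2)c(C)o1`: 24400 nM
Compound 3 `CCCN(CCC)CCNC(=O)C1CCN(Cc2nc(-c3ccccc3C)oc2C)CC1`: 30500 nM

In an ADME assay on Huh7.5.1 cells (Homo sapiens) for cytotoxicity, read by ATP content, with a stated time of 48 h (on this read-out lower numbers stand for higher toxicity in this test and higher numbers for lower toxicity in this test), compound 1 gives the lowest of the three numbers; compound 2 and compound 3 both stand clearly higher. Compound 4 `COc1cccc(C)c1-c1nc(CN2CCC(C(=O)NCCCN3C[C@H](C)C[C@H](C)C3)CC2)c(C)o1` is compound 1 with one change: 2-methoxy-6-methylphenyl in place of 2,6-dibromophenyl on an aromatic carbon. Going by the values given here, the only measured step, a 1.3-fold higher number from compound 2 to compound 3 (0.10 log units; within the scatter), alters a different part of the molecule and says nothing about the aryl group, and compound 2 and compound 3 differ from compound 1 in more than one place, so no measured step bears directly on this change. Compound 4 is therefore expected to stay near compound 1, with a modest shift toward the higher numbers of compound 2 and compound 3 plausible; the estimated step is a 1.7-fold higher number from compound 1 to compound 4 (0.23 log units; within the scatter). The estimate for compound 4 is 11000 nM, ranging from 4000 nM to 30000 nM.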

Compound 4, half-maximal cytotoxic concentration: 16700 nM
Beside the measured number, compound 4's estimate is 1.5-fold (0.18 log units) below it, within the range that was stated.
By their numbers in this assay, from the lowest: compound 1; then compounds 4, 2 and 3 (each within the scatter of the next).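

In this assay replacing 2,6-dibromophenyl with 2-methoxy-6-methylphenyl gives a 2.6-fold higher number from compound 1 to compound 4 (0.41 log units; beyond the scatter) and so points to lower toxicity in this test. Going by these compounds alone, this is the first step read at this position, and it shows that the aryl group alone can shift the number modestly while the rest of the molecule stays the same. Nothing available explains the shift. Still open, on these data alone, is whether losing the bromine atoms or gaining the methoxy group matters more, and how a 2,6-dichlorophenyl or 2,6-dimethoxyphenyl group would read here.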